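The compounds below may be only part of what the source reports. "The series", "measured", "known", "first", "only" and "open" are said of these compounds alone.

Measured so far:
Compound 1, `CN1C[C@H](C(=O)Nc2ccccc2)[C@@H](c2ccc(/C=C/C(=O)Nc3ccccc3N)cc2)C1`: 67 mL/min/kg
Compound 2, `CN1C[C@H](C(=O)Nc2cccc(Cl)c2)[C@@H](c2ccc(/C=C/C(=O)Nc3ccccc3N)cc2)C1`: 58 mL/min/kg
Compound 3, `CN1C[C@H](C(=O)Nc2ccccn2)[C@@H](c2ccc(/C=C/C(=O)Nc3ccccc3N)cc2)C1`: 40 mL/min/kg

These three compounds were run in an in vitro ADME assay on microsomes from liver (Mus musculus) for pharmacokinetics, read by LC-MS, with a stated time of 10 min, tested at 1 uM (a lower number here means slower removal, a higher number faster removal of the compound), and the unmeasured compound 4, `CN1C[C@H](C(=O)Nc2ccc(Cl)cn2)[C@@H](c2ccc(/C=C/C(=O)Nc3ccccc3N)cc2)C1`, is to be tested there next. The step from compound 1 to compound 2 is chloro in place of hydrogen on an aromatic carbon, and it gave a 1.2-fold lower number from compound 1 to compound 2 (0.06 log units; within the scatter). The cores of compound 1 and compound 3 differ by pyridin-2-yl in place of phenyl on an amide-type nitrogen, a change that brought a 1.7-fold lower number from compound 1 to compound 3 (0.22 log units; within the scatter), while compound 2 and compound 3 are separated by a 1.5-fold lower number from compound 2 to compound 3 (0.16 log units; within the scatter). Compound 4 arises from compound 3 by chloro in place of hydrogen on an aromatic carbon. Within the data shown here, this is the same kind of change as the one from compound 1 to compound 2, not the same: there the place was on an aromatic carbon of a six-membered aromatic ring of carbon only, meta to a large group, whereas here it is on a six-membered aromatic ring with 1 nitrogen, two atoms from the ring nitrogen, para to a large group. Since the earlier step gave a 1.2-fold lower number from compound 1 to compound 2 (0.06 log units; within the scatter), a step of similar size is expected, namely a 1.1-fold lower number from compound 3 to compound 4 (0.05 log units; within the scatter). Compound 4 is therefore estimated at 36 mL/min/kg, with a range from 20 mL/min/kg to 62 mL/min/kg.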

Compound 4, clearance: 31 mL/min/kg
Compound 4: middle estimate off by 1.2-fold (0.06 log units), on the high side; measured number inside the range.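

In this assay, chloro in place of hydrogen on an aromatic carbon reads alike on the two cores: the same change on two cores in this assay, a 1.2-fold lower number (0.06 log units; within the scatter) from compound 1 to compound 2 and a 1.3-fold lower number (0.11 log units; within the scatter) from compound 3 to compound 4, 1.1-fold (0.05 log units) apart, within the scatter of two such steps. The new step, a 1.3-fold lower number from compound 3 to compound 4 (0.11 log units; within the scatter), lies within the scatter like the earlier one, so the two agree only in that neither can be told from repeat noise; they do not show that chloro reliably lowers the number on either core, and one pair per core, with the chloro at a different place on each ring, is thin support for any transfer rule. Only the combined change to 5-chloropyridin-2-yl goes beyond the scatter, and only modestly, as a 2.2-fold lower number from compound 1 to compound 4 (0.33 log units; beyond the scatter), whereas the same group in place of 3-chlorophenyl stays within it, as a 1.9-fold lower number from compound 2 to compound 4 (0.27 log units; within the scatter).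

The compounds shown leave open whether a fluoro, a methyl or a methoxy group at this place on the pyridin-2-yl ring would read the same way. They also leave open what a larger group on the ring nitrogen of the shared core, such as an ethyl group, would do.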